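A few compounds are considered here, and "the series" means these few. Any claim that something is new, unique, unknown or untested is made for them only; others in the source may bear on it.

Measured compounds:
- compound 1, `O=S(=O)(Nc1ccc2oc(-c3ccccc3)nc2c1)c1ccc(Cl)c(Cl)c1`, in an assay on cells for inhibition of HSP60/HSP10 (Homo sapiens), with a stated time of 60 min (on this read-out higher numbers stand for weaker inhibition and lower numbers for stronger inhibition), gives > 100000 nM, a limit of the assay and not a number.
- compound 2, `Cc1ccccc1S(=O)(=O)Nc1ccc(-c2nc3ccccc3o2)cc1`, in this assay gives 85000 nM.

Compound 1 stands only at a limit: the value the limit of > 100000 nM in this assay, at which 1 of the 2 values shown sits, marks the edge of what the assay reports, so its inhibition is known to be weak but not how weak. For the measured compounds named here, compound 2 is the one measured compound with a number, and that number also sits at the weak end of the read-out. Going by the values given here, no step between the two is given, so nothing is said here about their order.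

Compound 3, `O=S(=O)(Nc1ccc2oc(-c3ccccc3)nc2c1)c1cccc(O)c1`, is not yet measured. It differs from compound 1 in one place: 3-hydroxyphenyl in place of 3,4-dichlorophenyl on a sulfonyl sulfur. Since compound 1 rests on a limit, the expected step from it to compound 3 is estimated only loosely as an at least 1.6-fold lower number from compound 1 to compound 3 (0.22 log units; that floor lies within the scatter), a move toward somewhat stronger inhibition that may still lie close to the scatter. On this basis compound 3 is expected to give about 60000 nM in this assay, within a range from 15000 nM to 200000 nM.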

Compound 3, half-maximal inhibitory concentration: 76000 nM
For compound 3 the middle estimate is 1.3-fold (0.10 log units) below the measured one; low and high end bracket the measured number.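

For the compounds shown here, compound 3 is the first compound on the core of compound 1 to give a number rather than a limit in this assay, which shows that a change at this position can bring the read-out inside the range the assay reports. Putting 3-hydroxyphenyl in place of 3,4-dichlorophenyl on a sulfonyl sulfur gives an at least 1.3-fold lower number from compound 1 to compound 3 (0.11 log units; that floor lies within the scatter), and the number for compound 3 still sits at the weak end of the read-out. The true size of this step stays unknown, and only its floor can be stated, because compound 1 rests on a limit of the assay: the limit of > 100000 nM in this assay, at which 1 of the 3 values shown sits.

The compounds shown leave open whether the step follows from the entering hydroxyl or from the loss of the two chlorine atoms, a question that an unsubstituted phenyl or a 3-methoxyphenyl on the same sulfonyl sulfur would help to separate. They also leave open whether another group there, such as a carboxylic acid or an amine, would move the number clearly away from the weak end of the read-out.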